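Removing the methyl from the aromatic nitrogen of compound 2

The source may report more compounds than this note shows. Statements on the series, on what has been measured and on what is new or still open speak of the compounds shown alone.

compound 1 `COc1ccc2c(c1)c(/C=N\NC(=O)c1c[nH]c3ccc(Br)cc13)cn2Cc1ccc(Cl)cc1`: 5000 nM
compound 2 `COc1ccc2c(c1)c(/C=N\NC(=O)c1cn(C)c3ccccc13)cn2Cc1ccc(Cl)cc1`: > 100000 nM

In a functional assay on MDA-MB-231 cells (Homo sapiens) for cytotoxicity (a lower number here means a stronger inhibitor, a higher number a weaker inhibitor), compound 1 gives 5000 nM. Compound 2 returns only the assay limit, > 100000 nM, so it stands at the limit of > 100000 nM in this assay, at which 1 of the 2 values shown sits, and not at a number. Compound 3 `COc1ccc2c(c1)c(/C=N\NC(=O)c1c[nH]c3ccccc13)cn2Cc1ccc(Cl)cc1` differs from compound 2 by hydrogen in place of methyl on an aromatic nitrogen. For the measured compounds named here, the only measured step, an at least 20-fold higher number from compound 1 to compound 2 (1.30 log units; beyond the scatter), bears on this change, but it combines loss of the bromine with gain of the methyl, so the share of the methyl alone cannot be read from it. The expected step, an at least 2.5-fold lower number from compound 2 to compound 3 (0.39 log units; beyond the scatter), points to a lower number. Compound 3 is estimated at 40000 nM, within 8000 nM to 200000 nM.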

Compound 3, half-maximal inhibitory concentration: 82700 nM
The estimate for compound 3 lay 2.1-fold (0.32 log units) below the measured number; measured number inside the range.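

In this assay, the bromo group accounts for a measurable loss on its own: hydrogen in place of bromo on an aromatic carbon gives a 17-fold higher number from compound 1 to compound 3 (1.22 log units; beyond the scatter), with no methyl involved. At the aromatic nitrogen, the change from methyl to hydrogen gives an at least 1.2-fold lower number from compound 2 to compound 3 (0.08 log units; that floor lies within the scatter), so no effect of the methyl can be resolved. Compound 2 gives only a limit, not a number: the limit of > 100000 nM in this assay, at which 1 of the 3 values shown sits.

On these data alone, the effect of methyl on the aromatic nitrogen with bromo retained remains open. So does whether a nitrile or an amine on that aromatic carbon would match bromo.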